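The source may hold more compounds than are shown below. What is called first, only, known or untested is meant among the compounds shown, and "the series" means these compounds.

Compound 1 `O=C1N=C(N2CCC[C@H]2C(=O)Nc2ccc3ncnc(Nc4cccc(Cl)c4)c3c2)S/C1=C/c1ccccc1Cl` — > 50000 nM (a limit of the assay, not a number)
Compound 2 `O=C1N=C(N2CCC[C@H]2C(=O)Nc2ccc3ncnc(Nc4cccc(Cl)c4)c3c2)S/C1=C/c1cccnc1` — 10400 nM
Compound 3 `O=C1N=C(N2CCC[C@H]2C(=O)Nc2ccc3ncnc(Nc4cccc(Cl)c4)c3c2)S/C1=C/c1ccc(-c2ccccc2)cc1` — 24200 nM

The three measured compounds share one core and differ only in the group on a double-bonded chain carbon bound to a double-bonded ring carbon. In a functional assay on A549 cells (Homo sapiens) for antiproliferative activity, read by MTT assay (a higher number here means a weaker inhibitor, a lower number a stronger inhibitor), compound 1 reaches only the limit of the assay, > 50000 nM, so no number is known for it. Compound 2, carrying pyridin-3-yl, gives 10400 nM. Compound 3, carrying 4-phenylphenyl, gives 24200 nM and thus stands at the higher of the two numbers, with compound 2 nearest to it, a 2.3-fold higher number from compound 2 to compound 3 (0.37 log units; beyond the scatter). Relative to the limit of compound 1, the step is an at least 2.0-fold lower number from compound 1 to compound 3 (0.31 log units; beyond the scatter), while compound 2 shows an at least 4.8-fold lower number from compound 1 to compound 2 (0.68 log units; beyond the scatter).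

Compound 4 `O=C1N=C(N2CCC[C@H]2C(=O)Nc2ccc3ncnc(Nc4cccc(Cl)c4)c3c2)S/C1=C/c1cccs1` makes one change from compound 3: thiophen-2-yl in place of 4-phenylphenyl on a double-bonded chain carbon bound to a double-bonded ring carbon. Among the compounds with values here, no measured step swaps exactly these two groups. The nearest guide is the move from 4-phenylphenyl to a small heteroaryl, seen in reverse in a 2.3-fold higher number from compound 2 to compound 3 (0.37 log units; beyond the scatter), which is modest. A similar modest lowering is therefore expected, as a 1.7-fold lower number from compound 3 to compound 4 (0.24 log units; within the scatter). Compound 4 is expected to give about 14000 nM, within 5000 nM to 45000 nM.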

Compound 4, half-maximal inhibitory concentration: 6100 nM
The estimate for compound 4 lay 2.3-fold (0.36 log units) above the measured number; low and high end bracket the measured number.
By their numbers in this assay, from the lowest: compounds 4 and 2 (each within the scatter of the next); then compound 3. At a limit, above all of these: compound 1.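

In this assay, replacing 4-phenylphenyl with thiophen-2-yl gives a 4.0-fold lower number from compound 3 to compound 4 (0.60 log units; beyond the scatter), the first measured step showing that a five-membered ring with one sulfur atom is better placed here than the two-ring group. Thiophen-2-yl and pyridin-3-yl cannot be told apart, with a 1.7-fold lower number from compound 2 to compound 4 (0.23 log units; within the scatter), so a single aromatic ring of either size gives a similar result in these two compounds. Ring size alone does not explain the series, as compound 1 also has a single aromatic ring, yet it reaches only a limit, which makes an at least 8.1-fold lower number from compound 1 to compound 4 (0.91 log units; beyond the scatter) a bound rather than a measured size: the limit of > 50000 nM in this assay, at which 1 of the 4 values shown sits.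

Going by these compounds, it remains open whether the chlorine or the phenyl ring itself sets compound 1 apart, which plain phenyl could test. Also open, on these data alone, is how an amine or a carboxylic acid on the thiophene ring would change the number.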